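Adding a 3-Fluorobenzyl Group to Compound 2

This account rests on a few compounds, and the source may have more. Where it says the series, first, only, none or still open, it means among the compounds named here.

Among the measured compounds shown here, compound 2 `CCCCC#Cc1nc(N)c2ncn([C@H]3[C@H](O)[C@H](O)[C@@H]4C[C@@H]43)c2n1` stands highest of the two numbers so far in an assay on RBL-2H3 cells for displacement of a labelled ligand from adenosine receptor A3 (Rattus norvegicus), with a stated time of 60 min (on this read-out lower numbers stand for stronger inhibition and higher numbers for weaker inhibition), where compound 2 gives 65 nM. For the measured compounds named here, its nearest neighbour, compound 1 `CCCCC#Cc1nc(NCc2cccc(Cl)c2)c2ncn([C@H]3[C@H](O)[C@H](O)[C@@H]4C[C@@H]43)c2n1`, gives 10.7 nM in this assay, and the step of a 6.1-fold higher number from compound 1 to compound 2 (0.78 log units; beyond the scatter) is the only measured step that bears on the change now considered. Compound 3 `CCCCC#Cc1nc(NCc2cccc(F)c2)c2ncn([C@H]3[C@H](O)[C@H](O)[C@@H]4C[C@@H]43)c2n1` differs from compound 2 by 3-fluorobenzyl in place of hydrogen on a nitrogen on an aromatic ring. This is the reverse of the measured step in kind, a 3-fluorobenzyl group entering where a 3-chlorobenzyl group had left; the data hold no direct comparison of the two benzyl groups. Because the step of a 6.1-fold higher number from compound 1 to compound 2 (0.78 log units; beyond the scatter) lay beyond the scatter, a lower number of comparable size is expected for compound 3, with some allowance for the untested exchange of halogen. Compound 3 is therefore estimated to give 15 nM in this assay, within a range of 6 nM to 40 nM. That expected step reads a 4.3-fold lower number from compound 2 to compound 3 (0.64 log units; beyond the scatter).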

Compound 3, inhibition constant: 43 nM
For compound 3 the middle estimate is 2.9-fold (0.46 log units) below the measured one; the measured number lies above the stated range.
By their numbers in this assay, from the lowest: compound 1; then compounds 3 and 2 (each within the scatter of the next).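

Placing 3-fluorobenzyl on the nitrogen gives a 1.5-fold lower number from compound 2 to compound 3 (0.18 log units; within the scatter) in this assay, so at this nitrogen a halogen-bearing benzyl group does not by itself set a compound apart from the free amino compound. Among the compounds shown here, the single exchange on the aromatic carbon, fluoro in place of chloro, gives a 4.0-fold higher number from compound 1 to compound 3 (0.60 log units; beyond the scatter), which shows that the number depends on which halogen the benzyl group carries, and that the gap seen earlier between the 3-chlorobenzyl compound and the free amino compound does not carry over to its fluoro counterpart. Nothing at hand accounts for this difference between the two halogens. The compounds shown leave open where a plain benzyl group on the nitrogen would fall. They also leave open whether bromo or methoxy on that aromatic carbon would track chloro or fluoro.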